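The compounds below may be only part of what the source reports. "The series", "measured", "known", "first", "only" and "open" are said of these compounds alone.

Measured compounds:
compound 1 `C[C@]1(O)C[C@@](c2cccc(C(F)(F)F)c2)([C@H](O)c2ccccn2)C1`: 300 nM
compound 2 `O[C@H](c1ccccn1)C1(c2ccc(OC(F)(F)F)cc2)CCC1`: 140 nM
compound 3 `O[C@@]1(c2ccccn2)CC[C@@H](c2ccc(C(F)(F)F)cc2)C1`: 240 nM

All three numbers come from an assay on HEK293 cells for antagonist activity at transient receptor potential cation channel subfamily V member 3 (Homo sapiens), read by FLIPR and calcium flux; a lower number here means a stronger inhibitor, a higher number a weaker inhibitor. In this assay compound 3 gives 240 nM, the second highest of the three numbers; its gap to compound 1 and its gap to compound 2 both fall within the scatter, so nothing separates these three compounds on the numbers in hand. For the measured compounds named here, no pair of measured compounds differs in a single place, so no measured step is available as a guide.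

Compound 4 `O[C@@]1(c2ccccn2)CC[C@H](c2ccc(C(F)(F)F)cc2)C1` is the counterpart of compound 3 that differs as follows: the two compounds have the same atoms and bonds and differ only in configuration as drawn: 1 of 2 stereo elements differ; a stereocentre at a saturated ring carbon is drawn R in compound 3 and S in compound 4. Inversion at a ring stereocentre can leave the number unchanged or move it well beyond the scatter in either direction, and the measured compounds contain no such inversion to judge by. The direction is therefore open; a step of moderate size in this assay is expected, with wide uncertainty. Compound 4 is expected to give about 450 nM in this assay, within 90 nM to 2500 nM. The expected step is a 1.9-fold higher number from compound 3 to compound 4 (0.27 log units; within the scatter).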

Compound 4, antagonist equilibrium constant: 610 nM
Compound 4: middle estimate off by 1.4-fold (0.13 log units), on the low side, within the range that was stated.
By their numbers in this assay, from the lowest: compounds 2, 3 and 1 (each within the scatter of the next, the first and the last beyond it); then compound 4.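

In this assay, for the compounds shown here, inversion at the saturated ring carbon gives a 2.5-fold higher number from compound 3 to compound 4 (0.41 log units; beyond the scatter), so this stereocentre is not silent: the earlier compounds offered no single-place comparison, and their numbers could not be told apart. Within this pair, the configuration drawn R carries the lower number, which gives the series its first step beyond the scatter, though a modest one. The step can be assigned to this inversion alone because of one structural fact: the fact that compounds 3 and 4 differ only in the configuration as drawn

From the compounds shown here alone, this is one pair, so it remains open whether the same preference would hold with an amine or a carboxylic acid in place of the trifluoromethyl group. Going by these compounds, the contribution of the other stereo element, which is the same in both compounds, also remains open.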